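Ring expansion of the amide in the sulfonylpiperazine amides

The source may hold more compounds than are shown below. What is called first, only, known or untested is meant among the compounds shown, and "the series" means these compounds.

Compound 1 `CCN(CC)C(=O)C(C)N1CCN(S(=O)(=O)c2ccc(C(C)(C)C)cc2)CC1` and compound 2 `CC(C(=O)N1CCCCC1)N1CCN(S(=O)(=O)c2ccc(C(C)(C)C)cc2)CC1` share the same core and differ only in the amine on the carbonyl carbon. In an ADME assay on HepG2 cells (Homo sapiens) for inhibition, with a stated time of 48 h (a lower number here means that less compound is needed, a higher number that more compound is needed for the effect), compound 1 gives only a limit, > 40000 nM. In this assay compound 2 likewise gives only a limit, > 40000 nM. The step that the two limits leave unreadable from compound 1 to compound 2 therefore cannot be read, since the limit of > 40000 nM in this assay, at which 2 of the 2 values shown sit, covers both values shown. Compound 2 thus stands at the upper edge of the numbers shown, with no measured value beneath it.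

Compound 3 `CC(C(=O)N1CCCCCC1)N1CCN(S(=O)(=O)c2ccc(C(C)(C)C)cc2)CC1` carries the change (azepan-1-yl in place of piperidin-1-yl on a carbonyl carbon). Going by the values given here, the only measured step, from compound 1 to compound 2, also exchanged the amine on the carbonyl carbon and left no readable size, so no direction can be drawn from it. Compound 3 is expected to sit at the same limit, with the step that the limit leaves unreadable from compound 2 to compound 3 expected to lie within the scatter. The estimate for compound 3 in this assay is 80000 nM, in the range 30000 nM to 300000 nM.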

Compound 3, half-maximal effective concentration: > 40000 nM
Compound 3: a limit, no number; the forecaster's own chance of this, stated with the estimate: 85%; the middle value does not contradict the limit.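

Compound 1, compound 2 and compound 3 all give only limits in this assay, so no step among them can be read: the limit of > 40000 nM in this assay, at which 3 of the 3 values shown sit.

The compounds shown leave open whether any amine on the carbonyl carbon of the shared core gives a measurable half-maximal effective concentration in this assay.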